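A second methoxy on the chalcone of compound 1

The source may report more compounds than this note shows. Statements on the series, on what has been measured and on what is new or still open speak of the compounds shown alone.

Compound 1, `COc1ccc(/C=C/C(=O)c2ccc(OCc3cn(CCNc4ccnc5cc(Cl)ccc45)nn3)cc2)cc1`: 35600 nM
Compound 2, `COc1ccc(C2CC(c3ccc(OCc4cn(CCNc5ccnc6cc(Cl)ccc56)nn4)c(OC)c3)=NN2C(C)=O)cc1OC`: 42700 nM

Both measurements come from an ADME assay on HeLa cells (Homo sapiens) for cytotoxicity, read by trypan blue exclusion, with a stated time of 24 h; on this read-out higher numbers stand for weaker inhibition and lower numbers for stronger inhibition. Compound 1 gives the lower of the two numbers, and compound 2 lies within the scatter of it, so neither can be called the stronger. Compound 3, `COc1ccc(/C=C/C(=O)c2ccc(OCc3cn(CCNc4ccnc5cc(Cl)ccc45)nn3)cc2)cc1OC`, differs from compound 1 by methoxy in place of hydrogen on an aromatic carbon. For the measured compounds named here, no measured pair shows the effect of such a change, so nothing beyond the scatter is expected in this assay, in either direction. The estimate for compound 3 is 38000 nM, between 15000 nM and 95000 nM, an expected step of a 1.1-fold higher number from compound 1 to compound 3 (0.03 log units; within the scatter).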

Compound 3, half-maximal inhibitory concentration: 12700 nM
Compound 3: the middle estimate sits 3.0-fold (0.48 log units) above what was measured; measured number outside the range, below it.
By their numbers in this assay, from the lowest: compound 3; then compounds 1 and 2 (each within the scatter of the next).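

In this assay, for the compounds shown here, methoxy in place of hydrogen on this aromatic carbon, ortho to a methoxy group, gives a 2.8-fold lower number from compound 1 to compound 3 (0.45 log units; beyond the scatter) and is the first single change with a readable effect. The position therefore responds: going from 4-methoxyphenyl to 3,4-dimethoxyphenyl moves the number beyond the scatter, toward stronger inhibition. Nothing measured here explains the shift. As far as these compounds go, whether this response is special to methoxy remains open. A hydroxyl, an amine or a longer chain such as ethoxy on the same carbon could tell.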